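Dimethylamino in place of chloro: expected efficacy of compound 4

A few compounds are considered here, and "the series" means these few. Any claim that something is new, unique, unknown or untested is made for them only; others in the source may bear on it.

Three measured compounds set the frame. In an in vitro functional assay on HEK285-7 cells for antagonist activity at prostaglandin D2 receptor 2 (Homo sapiens), read by BRET and beta-arrestin recruitment (on this read-out lower numbers stand for smaller maximal responses and higher numbers for larger maximal responses), compound 1 `O=C(O)Cc1sc(C(c2ccc(F)cc2)c2ccc(F)cc2)nc1-c1ccnc(Cl)c1` gives 80%. Compound 2 `COc1ccc(C(c2ccccn2)c2nc(-c3ccc(Cl)cc3)c(CC(=O)O)s2)cc1` gives 80% in this assay, and compound 3 `O=C(O)Cc1sc(C(c2ccccc2)c2ccc(F)c(F)c2)nc1-c1ccc(F)cc1` gives 80%. Compound 1 thus stands level with both at the digits shown, nearest compound 2 and furthest compound 3, with no change beyond the scatter in either direction. Compound 4 `CN(C)c1cc(-c2nc(C(c3ccc(F)cc3)c3ccc(F)cc3)sc2CC(=O)O)ccn1` is not yet measured; it differs from compound 1 by dimethylamino in place of chloro on an aromatic carbon, the same difference read one bond further out being 2-chloropyridin-4-yl to 2-(dimethylamino)pyridin-4-yl. Within the data shown here, no step between measured compounds covers this exchange, so the step of no change at the digits printed from compound 1 to compound 4 (within the scatter) is expected to be small, with no direction beyond the scatter. Compound 4 is estimated at 80%, between 62% and 95%.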

Compound 4, largest response reached (reported as efficacy), in percent of the reference or control that the assay uses: 80%
Beside the measured number, compound 4's estimate shows no gap at the digits printed; the range from low to high includes it.
By their numbers in this assay, from the lowest: compounds 1, 2, 3 and 4 (each within the scatter of the next).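

In this assay, dimethylamino in place of chloro gives no change at the digits printed from compound 1 to compound 4 (within the scatter) as the first step read at this position, on an aromatic carbon next to the ring nitrogen. The position therefore takes dimethylamino, with its hydrogen-bond acceptor, without a shift in maximal response beyond the scatter. No evidence on hand gives a reason for this result.

As far as these compounds go, whether a primary amine, a methoxy group or a longer chain such as diethylamino would read the same at this carbon stays open. Also open, from the compounds shown here alone, is whether the exchange reads the same with other groups on the shared core.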